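The source may hold more compounds than are shown below. What is called first, only, known or untested is meant among the compounds shown, and "the series" means these compounds.

Measured so far: compound 1 `COc1cc(OC)c(OC)cc1/C=C/COC(=O)/C=C/c1ccc(OC)c(OC)c1` with 0%; compound 2 `COc1cc(OC)c(OC)cc1/C=C/COC(=O)/C=C/c1c(OC)ccc(OC)c1OC` with 50%.

In a functional assay on the whole organism (strain Kunming) with Mus musculus as the target, with a stated time of 0.5 h, at a dose of 300 mg/kg by the intraperitoneal route (on this read-out higher numbers stand for a weaker effect at the one dose given and lower numbers for a stronger effect), compound 1 gives 0%, the lowest of the two numbers. Compound 2 gives 50% in this assay, a gap beyond the usual scatter; the two differ in more than one place, so their values show only that much and no single step can be read from them.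

Compound 3 `COc1cc(OC)c(OC)cc1/C=C/COC(=O)/C=C/c1ccccc1C(F)(F)F` has not yet been measured. It differs from compound 1 in one place: 2-(trifluoromethyl)phenyl in place of 3,4-dimethoxyphenyl on a double-bonded chain carbon bound to a double-bonded chain carbon. Among the compounds with values here, no measured pair shows a change of this kind, so there is no step to lean on. Because compound 1 gives 0%, the bottom of the scale in this assay, the step is expected to be upward or absent rather than downward, and a modest rise is the expectation: a number 20 percentage points higher from compound 1 to compound 3 (beyond the scatter). Compound 3 is thus estimated at 20%, with a range from 0% to 55%.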

Compound 3, a percentage reported as activity, at one dose (the size of the read-out at that dose, not a potency): 50%
The estimate for compound 3 lay 30 percentage points below the measured number, within the range that was stated.
By their numbers in this assay, from the lowest: compound 1; then compounds 2 and 3 (each within the scatter of the next).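

In this assay, within the data shown here, the swap of 3,4-dimethoxyphenyl for 2-(trifluoromethyl)phenyl on a double-bonded chain carbon bound to a double-bonded chain carbon gives the first step that can be read from a single change: a number 50 percentage points higher from compound 1 to compound 3 (beyond the scatter), a large step. What sits at this place therefore matters for the read-out, something compounds 1 and 2 could not show, as they differ in more than one place. Nothing measured here accounts for the size of this step.

The swap removes the two methoxy groups and brings in a trifluoromethyl group in one move, so the loss of the former and the gain of the latter cannot be told apart. On these data alone, how a plain phenyl, or a phenyl carrying an amine, would read at this place remains open.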